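From 1-hydroxyethyl to hydroxymethyl on a shared core

A few compounds are considered here, and "the series" means these few. Any claim that something is new, unique, unknown or untested is made for them only; others in the source may bear on it.

In an ADME assay on L1210 cells (Mus musculus) for cytotoxicity, with a stated time of 48 h (a higher number here means a weaker inhibitor, a lower number a stronger inhibitor), compound 1 `C=C1[C@H](C)CCC[C@]1(C)CC/C(C)=C/CC1=C(O)C(=O)C=C(NCC(=O)O)C1=O` gives 4 ug/mL. Compound 2 `C=C1[C@H](C)CCC[C@]1(C)CC/C(C)=C/CC1=C(O)C(=O)C=C(N[C@H](C(=O)O)[C@H](C)O)C1=O` reads > 10 ug/mL, which is a limit of the assay and not a number. Going by the values given here, only one measured step bears on what follows: an at least 2.5-fold higher number from compound 1 to compound 2 (0.39 log units; beyond the scatter), where 1-hydroxyethyl takes the place of hydrogen on a saturated chain carbon bound to an amine nitrogen and a carbonyl carbon. Compound 3 `C=C1[C@H](C)CCC[C@]1(C)CC/C(C)=C/CC1=C(O)C(=O)C=C(N[C@@H](CO)C(=O)O)C1=O` differs from compound 2 by hydrogen in place of methyl on a saturated chain carbon bound to an oxygen on a saturated carbon and a saturated chain carbon, with hydrogen in place of methyl on a saturated chain carbon bound to an oxygen on a saturated carbon and a saturated chain carbon, so that 1-hydroxyethyl becomes hydroxymethyl. Part of the rise seen from hydrogen to 1-hydroxyethyl is therefore expected to be given back. The expected move in this assay is an at least 1.4-fold lower number from compound 2 to compound 3 (0.15 log units; that floor lies within the scatter), toward a lower number. Compound 3 is estimated at 7 ug/mL, with an expected range of 3.5 ug/mL to 14 ug/mL.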

Compound 3, half-maximal inhibitory concentration: > 10 ug/mL
Compound 3 ended at the assay's limit; the forecaster's own chance of this, stated with the estimate: 30%; at least 1.4-fold (0.15 log units) between middle value and limit.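

In this assay, hydroxymethyl on the saturated chain carbon bound to an amine nitrogen and a carbonyl carbon also gives an at least 2.5-fold higher number from compound 1 to compound 3 (0.39 log units; beyond the scatter), so the rise is not confined to 1-hydroxyethyl. Hydrogen in place of methyl brings back no readable part of that rise. The step from compound 2 to compound 3 cannot be read because both compounds stand at the same limit of the assay: the limit of > 10 ug/mL in this assay, at which 2 of the 3 values shown sit.

As far as these compounds go, how far compound 2 and compound 3 lie past that limit remains open, and with it the size of any effect of the methyl. Also open, from the compounds shown here alone, is whether a plain methyl or a longer alkyl chain without a hydroxyl, on that same carbon, would raise the number as the two hydroxyl-bearing groups do.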